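Lengthening the bromo-ended chain once more

The source may report more compounds than this note shows. Statements on the series, on what has been measured and on what is new or still open speak of the compounds shown alone.

In a functional assay on HeLa cells (Homo sapiens) for antiproliferative activity, read by MTT assay, with a stated time of 48 h (on this read-out higher numbers stand for weaker inhibition and lower numbers for stronger inhibition), compound 1 `COc1ccc(N(C)c2ccnc(Cl)n2)cc1[N+](=O)[O-]` gives 4730 nM as its reading, compound 2 `COc1ccc(N(C)c2ccnc(Cl)n2)cc1OCCBr` gives 3310 nM as its reading, and compound 3 `COc1ccc(N(C)c2ccnc(Cl)n2)cc1OCCCCBr` gives 307 nM as the lowest number of the three, which makes it the strongest inhibitor here. Putting 2-bromoethoxy in place of nitro gave a 1.4-fold lower number from compound 1 to compound 2 (0.16 log units; within the scatter) as a small step, whereas 4-bromobutoxy in place of nitro gave a 15-fold lower number from compound 1 to compound 3 (1.19 log units; beyond the scatter) as a large one.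

Compound 4 `COc1ccc(N(C)c2ccnc(Cl)n2)cc1OCCCCCBr` differs from compound 3 in one place only, by bromomethyl in place of bromo on a saturated chain carbon, four bonds along the chain from an oxygen on an aromatic ring in this change: bromomethyl in place of bromo on a saturated chain carbon, four bonds along the chain from an oxygen on an aromatic ring. The closest guide is an 11-fold lower number from compound 2 to compound 3 (1.03 log units; beyond the scatter) as a change of chain alone, but this single large step cannot show whether further lengthening keeps lowering the number. No chain longer than that of compound 3 has been measured yet. So no step beyond the scatter is expected in this assay for now, with only a slight lean towards a lower number. The expected step is a 1.2-fold lower number from compound 3 to compound 4 (0.07 log units; within the scatter) by this estimate. For compound 4 the expected value is 260 nM within an estimated range of 80 nM to 850 nM for now.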

Compound 4, half-maximal inhibitory concentration: 7090 nM
Compound 4: the middle estimate sits 27-fold (1.44 log units) below what was measured; the measured number lies above the stated range.
By their numbers in this assay, from the lowest: compound 3; then compounds 2, 1 and 4 (each within the scatter of the next, the first and the last beyond it).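

One more carbon, bromomethyl in place of bromo on a saturated chain carbon, four bonds along the chain from an oxygen on an aromatic ring, wipes out the gain seen so far in this assay (a 23-fold higher number from compound 3 to compound 4 (1.36 log units; beyond the scatter)), so lengthening this chain does not steadily lower the number, and compound 4 goes against the fall seen from compound 2 to compound 3. Compound 4 also ends up weaker than the short-chain compound (a 2.1-fold higher number from compound 2 to compound 4 (0.33 log units; beyond the scatter)), although only modestly, and its step from the nitro compound lies within the scatter (a 1.5-fold higher number from compound 1 to compound 4 (0.18 log units; within the scatter)), so among these compounds the low number belongs to the 4-bromobutoxy chain of compound 3 alone. No measurement available here accounts for this sharp reversal.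

Going by these compounds, it remains open how a 3-bromopropoxy chain or a chain longer than 5-bromopentyl would read, and so whether the low number at 4-bromobutoxy is a narrow peak or part of a broader pattern. On these data alone, it is also open whether the bromine itself matters, which a 4-carbon chain ending in an amine or a hydroxyl group in its place could test.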